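A few compounds are considered here, and "the series" means these few. Any claim that something is new, unique, unknown or untested is made for them only; others in the source may bear on it.

Measured compounds:
- compound 1 `COc1cc(F)cc(-c2cc3cc(C(=N)N)ccc3[nH]2)c1` — 77%
- compound 2 `N=C(N)c1ccc(-c2cc3cc(C(=N)N)ccc3[nH]2)cc1` — 39%
- compound 3 `Cc1cc(Cl)cc(-c2cc3cc(C(=N)N)ccc3[nH]2)c1` — 87%

In an assay on isolated protein for inhibition of acid-sensing ion channel 3 (Homo sapiens), read by patch clamp, tested at 1 uM (a lower number here means less inhibition, a higher number more inhibition at the concentration tested (going by the name of the read-out)), compound 3 holds the highest of the three numbers, yet its gap to compound 1 lies within the scatter, so the two cannot be told apart; only compound 2 sits clearly lower. For the measured compounds named here, no two measured compounds differ in a single place, so no measured step exists to guide the next change. Compound 4 `N=C(N)c1ccc2[nH]c(-c3cc(Cl)cc(Cl)c3)cc2c1` differs from compound 3 by chloro in place of methyl on an aromatic carbon. Given that compound 3 reaches 87%, a small group swap of this kind is expected to move the number little: the step of a number 2 percentage points lower from compound 3 to compound 4 (within the scatter) is estimated to stay within the scatter, in no clear direction. Compound 4 is expected to give 85%, with a range from 70% to 95%.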

Compound 4, a percentage reported as inhibition, at one concentration (the size of the read-out at that concentration, not a potency): 92%
The estimate for compound 4 lay 7 percentage points below the measured number; low and high end bracket the measured number.
By their numbers in this assay, from the lowest: compound 2; then compounds 1, 3 and 4 (each within the scatter of the next, the first and the last beyond it).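

In this assay, for the compounds shown here, chloro in place of methyl on an aromatic carbon gives a number 5 percentage points higher from compound 3 to compound 4 (within the scatter), the first single-place step. At this position, meta to a chloro group and meta to a large group, the two groups cannot be told apart, and the number stays high with either. Nothing available explains this result. Going by these compounds, what an amine, a hydroxyl or a carboxylic acid would do at this position remains open. So does whether a longer chain there would keep the number in this range.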